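The source may report more compounds than this note shows. Statements on the series, on what has been measured and on what is new or still open speak of the compounds shown alone.

In a functional assay on brain (Rattus norvegicus, strain Wistar) for inhibition (a lower number here means a stronger inhibitor, a higher number a weaker inhibitor), three compounds sharing one core have been measured: compound 1 `Cc1[nH]c(=O)n(C)c1-c1ccc(OC(C)C)cc1` gives 20400 nM, compound 2 `CCCCCCc1ccc(-c2c(C)[nH]c(=O)n2C)cc1` gives 9000 nM, and compound 3 `Cc1[nH]c(=O)n(C)c1-c1ccc(C2CCCCC2)cc1` gives 10000 nM. Compound 2 thus lies within the scatter of compound 3, and both lie below compound 1. Compound 4 `CCCCCCCCCCCCc1ccc(-c2c(C)[nH]c(=O)n2C)cc1` differs from compound 2 by hexyl in place of hydrogen on a saturated chain carbon, six bonds along the chain from an aromatic carbon. Among the measured compounds shown here, no measured step lengthens a chain, so the evidence is only indirect. The nearest steps are a 2.3-fold lower number from compound 1 to compound 2 (0.36 log units; beyond the scatter) and a 2.0-fold lower number from compound 1 to compound 3 (0.31 log units; beyond the scatter), both modest, while a 1.1-fold higher number from compound 2 to compound 3 (0.05 log units; within the scatter) stays within the scatter. A modest move toward a lower number in this assay is therefore expected. The expected step is a 2.3-fold lower number from compound 2 to compound 4 (0.35 log units; beyond the scatter). For compound 4 the estimated value is 4000 nM, with an expected range from 800 nM to 20000 nM.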

Compound 4, half-maximal inhibitory concentration: 13000 nM
Estimate against measurement, compound 4: 3.3-fold (0.51 log units) below, within the range that was stated.
By their numbers in this assay, from the lowest: compounds 2, 3, 4 and 1 (each within the scatter of the next, the first and the last beyond it).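

In this assay, among the compounds shown here, hexyl in place of hydrogen on a saturated chain carbon, six bonds along the chain from an aromatic carbon, gives a 1.4-fold higher number from compound 2 to compound 4 (0.16 log units; within the scatter) and is the first step here that lengthens a chain. This position therefore accepts the added hexyl without a change that can be told from the scatter. No measured evidence bears on why this is so. Still open, going by these compounds, is whether a longer chain than that of compound 4 would stay within the scatter of compound 2. Also open, on these data alone, is whether an amine or a carboxylic acid carried on the chain would shift the number.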